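The source may report more compounds than this note shows. Statements on the series, on what has been measured and on what is new or still open speak of the compounds shown alone.

Measured compounds:
compound 1 `Cc1cc(S(=O)(=O)NC(=O)c2ccc(N3CCN(Cc4ccccc4-c4ccc(Cl)cc4)CC3)cc2)ccc1N[C@H](CCN(C)C)CSc1ccccc1`, < 1 nM
compound 2 `CN(C)CC[C@H](CSc1ccccc1)Nc1ccc(S(=O)(=O)NC(=O)c2ccc(N3CCN(Cc4ccccc4-c4ccc(Cl)cc4)CC3)cc2)cc1S(=O)(=O)C(F)(F)F`, < 1 nM

In an assay on isolated protein for displacement of a labelled ligand from Bcl2-associated agonist of cell death (Homo sapiens), read by fluorescence polarization (a higher number here means a weaker inhibitor, a lower number a stronger inhibitor), compound 1 gives < 1 nM, which is a limit of the assay rather than a number. Compound 2 gives < 1 nM, likewise a limit. The step that the two limits leave unreadable from compound 1 to compound 2 is therefore not readable, since both values sit at the limit of < 1 nM in this assay, at which 2 of the 2 values shown sit. Compound 2 thus stands only at a limit, with no numeric value to anchor it.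

Compound 3 `CN(C)CC[C@H](CSc1ccccc1)Nc1ccc(S(=O)(=O)NC(=O)c2ccc(N3CCN(Cc4ccccc4-c4ccc(Cl)cc4)CC3)cc2)cc1OC(F)(F)F` differs from compound 2 by trifluoromethoxy in place of (trifluoromethyl)sulfonyl on an aromatic carbon. Among the measured compounds shown here, no measured step is readable, so nothing bears directly on this change beyond the fact that both measured compounds sit at the limit. For the step that the limit leaves unreadable from compound 2 to compound 3 in this assay no shift beyond the scatter is expected. Compound 3 is estimated at 0.6 nM, with a range from 0.1 nM to 4 nM, and the expected outcome is that the assay again reports only a limit.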

Compound 3, inhibition constant: < 1 nM
Compound 3 gave a limit, no number; the forecaster's own chance of this, stated with the estimate: 70%; the middle value lies beyond the limit too.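

No step can be read among compound 1, compound 2 and compound 3 in this assay, because each gives only a limit and no number: the limit of < 1 nM in this assay, at which 3 of the 3 values shown sit.

The compounds shown leave open whether methyl, (trifluoromethyl)sulfonyl and trifluoromethoxy on this aromatic carbon differ in their effect on binding at all.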